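Working notes: the pendant phenyl substituent, compound 3 to compound 4

The source may report more compounds than this note shows. Statements on the series, on what has been measured and on what is new or still open speak of the compounds shown alone.

Three measured compounds share one core and differ only in the group carried on the pendant phenyl ring. Compound 1 `Cn1nc2c(=O)n(CC3(O)CCN(Cc4ccc(-c5ccco5)cc4Cl)CC3)cnc2c1-c1ccc(Cl)cc1` gives 143 nM in an assay on isolated protein for inhibition of ubiquitin carboxyl-terminal hydrolase 7 (Homo sapiens), with stated times of 30 min and 2 h; a higher number here means a weaker inhibitor, a lower number a stronger inhibitor. Compound 2 `Cn1nc2c(=O)n(CC3(O)CCN(Cc4ccc(-c5ccco5)cc4Cl)CC3)cnc2c1-c1ccc(C(N)=O)cc1` gives 80.8 nM in this assay. Compound 3 `Cn1nc2c(=O)n(CC3(O)CCN(Cc4ccc(-c5ccco5)cc4Cl)CC3)cnc2c1-c1ccc(C(=N)N)cc1` gives 87.5 nM in this assay. Compound 3 stands second highest of the three numbers; its nearest neighbour is compound 2 and its furthest is compound 1, and both gaps are within the scatter, so no order among the three can be read. The steps seen so far are a 1.8-fold lower number from compound 1 to compound 2 (0.25 log units; within the scatter), a 1.6-fold lower number from compound 1 to compound 3 (0.21 log units; within the scatter) and a 1.1-fold higher number from compound 2 to compound 3 (0.03 log units; within the scatter), each within the scatter.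

Compound 4 `CCCNCc1ccc(-c2c3ncn(CC4(O)CCN(Cc5ccc(-c6ccco6)cc5Cl)CC4)c(=O)c3nn2C)cc1` has not yet been measured. It differs from compound 3 in that (a group of 5 heavy atoms (4 carbon, 1 nitrogen; no ring) in place of a group of 3 heavy atoms (1 carbon, 2 nitrogen; no ring), on an aromatic carbon); the change sits on an aromatic carbon of a six-membered aromatic ring of carbon only, para to a large group. All three measured steps exchange the group at this same place and none of them moved the number beyond the scatter, so the expected step of a 1.0-fold higher number from compound 3 to compound 4 (0.01 log units; within the scatter) is small and of no firm direction. Among the measured compounds shown here, no measured step involves a (propylamino)methyl group, so the range is kept wide. Compound 4 is estimated at 90 nM, with a range from 40 nM to 250 nM.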

Compound 4, half-maximal inhibitory concentration: 43.9 nM
The estimate for compound 4 lay 2.1-fold (0.31 log units) above the measured number, within the range that was stated.
By their numbers in this assay, from the lowest: compounds 4, 2, 3 and 1 (each within the scatter of the next, the first and the last beyond it).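

In this assay, among the compounds shown here, the (propylamino)methyl group gives the first step at this position that lies beyond the scatter, though only a modest one, when it replaces chloro (a 3.3-fold lower number from compound 1 to compound 4 (0.51 log units; beyond the scatter)). Against the other two groups the change stays within the scatter (a 1.8-fold lower number from compound 2 to compound 4 (0.26 log units; within the scatter); a 2.0-fold lower number from compound 3 to compound 4 (0.30 log units; within the scatter)), so compound 4 cannot be ordered against compound 2 or compound 3, and this aromatic carbon, para to a large group, accepts the longer chain with no loss in the number. No measurement accompanies these compounds that could explain the difference from compound 1.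

On these data alone, it remains open whether the step from chloro belongs to the amine nitrogen, to the propyl chain or to both, and an aminomethyl group, a butylaminomethyl chain or a propoxymethyl group at the same carbon would help separate these. A carboxylic acid or a tertiary amine at this place would also show how far the series extends beyond the carbamoyl, amidine and secondary amine groups seen here.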